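A few compounds are considered here, and "the series" means these few. Any claim that something is new, unique, unknown or untested is made for them only; others in the source may bear on it.

The three measured compounds in a functional assay on the whole organism (strain Wistar) for inhibition, with Rattus norvegicus as the target, read by paw edema, with stated times of 60 min and 24 h, at a dose of 100 mg/kg by the oral route (a lower number here means less inhibition, a higher number more inhibition at the dose given (going by the name of the read-out)), are:

Compound 1 `CCCNC(=O)CC1CCc2cc(OC)c(OC)cc21` gives 26.7%.
Compound 2 `CCCCNC(=O)CC1CCc2cc(OC)c(OC)cc21` gives 36.7%.
Compound 3 `COc1cc2c(cc1OC)C(CC(=O)NC1CCCC1)CC2` gives 46.7%.

Compound 2 stands second highest of the three numbers; its nearest neighbour is compound 3, which reads a number 10 percentage points higher from compound 2 to compound 3 (within the scatter), and the other is compound 1, from which compound 2 is reached by a number 10 percentage points higher from compound 1 to compound 2 (within the scatter). Both of those gaps lie within the scatter, so no order among the three can be drawn from them. For the measured compounds named here, the only step beyond the scatter is a number 20 percentage points higher from compound 1 to compound 3 (beyond the scatter), a modest rise.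

Compound 4 `COc1cc2c(cc1OC)C(CC(=O)N1CCCC1)CC2` differs from compound 2 in one place: pyrrolidin-1-yl in place of butylamino on a carbonyl carbon. All three measured steps vary the group on the amide-type nitrogen, and the closest of them, a number 10 percentage points higher from compound 2 to compound 3 (within the scatter), also brings a five-membered ring in place of a butyl chain but keeps the amide hydrogen. Going by the values given here, no measured step removes that hydrogen, so there is no direct precedent. Given that the measured steps at this position are small, the step for compound 4 is expected to be none beyond the scatter, a number 1.7 percentage points lower from compound 2 to compound 4 (within the scatter), with compound 4 estimated at 35% (range 15% to 55%).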

Compound 4, a percentage reported as inhibition, in the whole organism at one dose (the size of the read-out at that dose, not a potency): 33.3%
Compound 4: the middle estimate sits 1.7 percentage points above what was measured; the measured number falls inside the stated range.
By their numbers in this assay, from the lowest: compounds 1, 4, 2 and 3 (each within the scatter of the next, the first and the last beyond it).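

In this assay, pyrrolidin-1-yl in place of butylamino on a carbonyl carbon gives a number 3.4 percentage points lower from compound 2 to compound 4 (within the scatter), and pyrrolidin-1-yl in place of propylamino gives a number 6.6 percentage points higher from compound 1 to compound 4 (within the scatter), so removing the amide hydrogen in this way leaves compound 4 not distinguishable from either open-chain amide. The comparison between the two ring-bearing groups does separate them, with a number 13.4 percentage points lower from compound 3 to compound 4 (beyond the scatter), which shows that a five-membered ring on this carbonyl carbon does not by itself go with the number seen for compound 3. Nothing available explains this gap.

The compounds shown leave open whether the amide hydrogen or the ring attachment accounts for the gap. Methyl(butyl)amino, which has no amide hydrogen and no ring, and piperidin-1-yl, a larger ring on the same nitrogen, would each help to separate these two features.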